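The compounds below may be only part of what the source reports. "The series", "measured", "known", "first", "only" and "open" are said of these compounds alone.

Three compounds sharing one core were examined in an assay on membranes from HeLa cells for displacement of a labelled ligand from adenosine receptor A3 (Homo sapiens), read by scintillation counting, with a stated time of 180 min, tested at 1 uM; a lower number here means less inhibition, a higher number more inhibition at the concentration tested (going by the name of the read-out). Compound 1 `CCCOC(=O)C1=C(C)NC(=O)NC1c1ccoc1` gives 11%, compound 2 `CC1=C(C(=O)OC(C)(C)C)C(c2ccoc2)NC(=O)N1` gives 2%, and compound 3 `CC1=C(C(N)=O)C(c2ccoc2)NC(=O)N1` gives 2%. Compound 3 thus stands level with compound 2 at the digits reported, the two together being the lowest of the three numbers, while compound 1 sits a number 9 percentage points lower from compound 1 to compound 3 (within the scatter) in the other direction, so that all three values lie within the scatter of one another.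

The next step leads to compound 4 `CCC(CC)OC(=O)C1=C(C)NC(=O)NC1c1ccoc1`, which differs from compound 3 by (pentan-3-yl)oxy in place of amino on a carbonyl carbon. Among the compounds with values here, two measured steps bear on this change, since both alter the same carbonyl carbon. Replacing propoxy by amino gave a number 9 percentage points lower from compound 1 to compound 3 (within the scatter), and replacing tert-butoxy by amino gave no change at the digits printed from compound 2 to compound 3 (within the scatter). Neither exchange of an alkoxy group for amino moved this assay beyond its scatter, and the reverse exchange to a (pentan-3-yl)oxy group is therefore not expected to do so either; if anything, a small drift back toward the level of compound 1 would be consistent with what is seen. Compound 4 is accordingly expected to give 8%, with a range from 0% to 20%. This amounts to an expected a number 6 percentage points higher from compound 3 to compound 4 (within the scatter), a step of no consequence beyond the scatter.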

Compound 4, a percentage reported as inhibition, at one concentration (the size of the read-out at that concentration, not a potency): 5%
The estimate for compound 4 lay 3 percentage points above the measured number, and the stated range covers the measured number.
By their numbers in this assay, from the lowest: compounds 2, 3, 4 and 1 (each within the scatter of the next).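

The (pentan-3-yl)oxy group extends what is known about this carbonyl carbon to a larger alkoxy group: in this assay, exchanging amino for it gives a number 3 percentage points higher from compound 3 to compound 4 (within the scatter) and thus stays within the scatter, although 6 heavy atoms without a hydrogen-bond donor replace 1 heavy atom with one. The comparisons among the alkoxy groups read the same way, with pentan-3-yl in place of tert-butyl giving a number 3 percentage points higher from compound 2 to compound 4 (within the scatter) and ethyl in place of hydrogen on the saturated chain carbon giving a number 6 percentage points lower from compound 1 to compound 4 (within the scatter), both also within the scatter. No step among the four compounds therefore lies beyond the scatter, and nothing available explains this lack of separation.

From the compounds shown here alone, it remains open whether any group on this carbonyl carbon would give a step beyond the scatter, such as a hydroxyl group that makes a carboxylic acid, a dimethylamino group or a longer chain on the oxygen. With one concentration in this series, this assay also leaves potency at the receptor undefined, and changes elsewhere on the shared core remain untested in what is shown here.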